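A few compounds are considered here, and "the series" means these few. Any claim that something is new, unique, unknown or untested is made for them only; others in the source may bear on it.

Working notes on the macrocyclic series.

Three members of the series have been tested in an ADME assay on Huh-7 cells (Homo sapiens) for cytotoxicity; on this read-out higher numbers stand for lower toxicity in this test and lower numbers for higher toxicity in this test. Compound 1 `CCC[C@H](NC(=O)[C@@H]1C[C@@H]2CN1C(=O)[C@H](C(C)(C)C)NC(=O)OCCCCCc1cccc3c1CN(C3)C(=O)O2)C(=O)C(=O)NC1CC1` reads > 50000 nM in this assay, a limit of the assay rather than a number. Compound 2 `CCC[C@H](NC(=O)[C@@H]1C[C@@H]2CN1C(=O)[C@H](C1CCCC1)NC(=O)OCCCCCCc1cccc3c1CN(C3)C(=O)O2)C(=O)C(=O)CC1CC1` likewise reads > 50000 nM, again a limit. Compound 3 `CCC[C@H](NC(=O)[C@@H]1C[C@@H]2CN1C(=O)[C@H](C(C)(C)C)NC(=O)OCCCCCCc1cccc3c1CN(C3)C(=O)O2)C(=O)C(=O)NC(C)CC` also gives > 50000 nM, once more a limit and not a measured value. Thus compound 3 stands at the limit of > 50000 nM in this assay, at which 3 of the 3 values shown sit, with nothing to separate it from the other two measured compounds: no step between any pair of measured compounds can be stated, and the three values show only that none of them reached a measurable cytotoxic concentration.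

The next compound, compound 4 `CCC[C@H](NC(=O)[C@@H]1C[C@@H]2CN1C(=O)[C@H](C(C)(C)C)NC(=O)OCCCCCCc1cccc3c1CN(C3)C(=O)O2)C(=O)C(=O)NCc1ccccn1`, differs from compound 3 at one place: (pyridin-2-yl)methyl in place of sec-butyl on an amide-type nitrogen. For the measured compounds named here, no measured step in this assay exists to guide the size of the change, and the shared core is unchanged. The expectation is that compound 4 remains at the assay limit, with a step from compound 3 to compound 4 of a number no higher from compound 3 to compound 4 (the limit leaves the size open), none beyond the scatter. Compound 4 is therefore estimated at 50000 nM in this assay, with a range of 30000 nM to 60000 nM.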

Compound 4, half-maximal cytotoxic concentration: > 50000 nM
Compound 4: a limit, no number; the forecaster's own chance of this, stated with the estimate: 85%; the middle value lies on the limit itself.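

The step from compound 3 to compound 4 cannot be read, as both values in this assay are limits and not numbers. The compounds shown leave open how the macrocyclic series ranks for cytotoxicity, and which changes to it would shift the read-out: the limit of > 50000 nM in this assay, at which 4 of the 4 values shown sit.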